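A few compounds are considered here, and "the series" means these few. Any claim that something is new, unique, unknown or untested is made for them only; others in the source may bear on it.

Three compounds share one core and differ only in a single group on an aromatic carbon. In an ADME assay on HEK-293T cells (Homo sapiens) for antiproliferative activity, read by MTT assay, with a stated time of 48 h, in the presence of a further agent that is not named here (a higher number here means that more compound is tolerated, a lower number that less compound is tolerated), compound 1 `Cc1ccc(-c2nn(-c3ccccc3)cc2C(=O)NOCc2ccccc2F)cc1` gives 20600 nM, compound 2 `COc1ccc(-c2nn(-c3ccccc3)cc2C(=O)NOCc2ccccc2F)cc1` gives 24600 nM, and compound 3 `O=C(NOCc1ccccc1F)c1cn(-c2ccccc2)nc1-c1ccc(Cl)cc1` gives 126000 nM, the highest of the three numbers; the step of a 6.1-fold higher number from compound 1 to compound 3 (0.79 log units; beyond the scatter) and the step of a 5.1-fold higher number from compound 2 to compound 3 (0.71 log units; beyond the scatter) both go beyond the scatter, whereas a 1.2-fold higher number from compound 1 to compound 2 (0.08 log units; within the scatter) stays within it. Compound 4 `O=C(NOCc1ccccc1F)c1cn(-c2ccccc2)nc1-c1ccc(F)cc1` carries fluoro in place of chloro on an aromatic carbon. Going by the values given here, no measured step swaps one halogen for another, so the two chloro steps are the only guide, and they show that this group shifts this assay modestly. A modest fall is expected from compound 3 to compound 4, a 2.5-fold lower number from compound 3 to compound 4 (0.40 log units; beyond the scatter). Compound 4 is therefore estimated at 50000 nM, within a range from 20000 nM to 150000 nM.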

Compound 4, half-maximal cytotoxic concentration: 147000 nM
The estimate for compound 4 lay 2.9-fold (0.47 log units) below the measured number; the measured number falls inside the stated range.
By their numbers in this assay, from the lowest: compounds 1 and 2 (each within the scatter of the next); then compounds 3 and 4 (each within the scatter of the next).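

Within the scatter, 4-chlorophenyl and 4-fluorophenyl cannot be told apart at this position, para to a large group, in this assay (a 1.2-fold higher number from compound 3 to compound 4 (0.07 log units; within the scatter)). The fluoro group also stands clear of the methoxy group (a 6.0-fold higher number from compound 2 to compound 4 (0.78 log units; beyond the scatter)) and the methyl group (a 7.1-fold higher number from compound 1 to compound 4 (0.85 log units; beyond the scatter)), so among these compounds the two halogens form one level and methyl and methoxy another. No measurement shown here accounts for this split.

Where an amine or a carboxylic acid on this carbon would fall remains open. So does whether the split holds on a different core.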